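The compounds below may be only part of what the source reports. "The series", "measured", "known", "first", "only" and "open" are said of these compounds alone.

Measured so far in a functional assay on MCF7 cells (Homo sapiens) for antiproliferative activity; a lower number here means a stronger inhibitor, a higher number a weaker inhibitor:
compound 1 `C/C(=C\Cn1cnc2c(Cl)ncnc21)CCC(=O)O`: > 100000 nM
compound 2 `C/C(=C\Cn1cnc(C(N)=O)n1)CCC(=O)O`: > 100000 nM

Neither entry is a number, since each is a limit of the assay, so no order can be drawn between the two compounds. Compound 2 reads > 100000 nM, which is a limit and gives it no measured potency. The picture so far is simply (the limit of > 100000 nM in this assay, at which 2 of the 2 values shown sit).

The next compound to be tested is compound 3 `C/C(=C\Cn1cnc(C(=O)O)n1)CCC(=O)O`. It keeps the rest of compound 2 and alters a single group: hydroxy in place of amino on a carbonyl carbon. This is hydroxy in place of amino on a carbonyl carbon, or carbamoyl to carboxy when cut one bond further out.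

Within the data shown here, no step between measured compounds offers a guide to the size of this change. With only limits to start from, no shift beyond the scatter is expected in this assay, in either direction. The estimated change is a number no higher from compound 2 to compound 3 (the limit leaves the size open). For compound 3 the expected value is 100000 nM. The estimated range for compound 3 runs from 40000 nM to 250000 nM, and a further limit is the likeliest report.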

Compound 3, half-maximal inhibitory concentration: > 100000 nM
Compound 3: a limit, no number; the forecaster's own chance of this, stated with the estimate: 85%; the middle value sits exactly at the limit.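

In this assay compound 3 reads > 100000 nM and this is a limit of the assay, not a number. Among these compounds, compound 2 also stands at a limit, so no step from compound 2 to compound 3 can be read. The compounds shown leave open how they rank against one another and what potency any of them has: the limit of > 100000 nM in this assay, at which 3 of the 3 values shown sit.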